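The source may hold more compounds than are shown below. What is called first, only, known or untested is meant among the compounds shown, and "the series" means these compounds.

Measured so far in an ADME assay on MCF7 cells (Homo sapiens) for cytotoxicity, read by MTT assay, with a stated time of 48 h; on this read-out lower numbers stand for stronger inhibition and higher numbers for weaker inhibition:
compound 1 `Fc1ccc(-c2[nH]c3cc(F)ccc3c2Cn2cncn2)cc1` gives > 1000000 nM.
compound 2 `Fc1ccc(-c2[nH]c3cc(Cl)ccc3c2Cn2cncn2)cc1` gives 625000 nM.
compound 3 `COc1ccc2c(Cn3cncn3)c(-c3ccc(F)cc3)[nH]c2c1` gives 12200 nM.

For compound 1 the value is a limit of the assay, not a number (the limit of > 1000000 nM in this assay, at which 1 of the 3 values shown sits). Compound 2 carries chloro in place of fluoro on an aromatic carbon; the step is an at least 1.6-fold lower number from compound 1 to compound 2 (0.20 log units; that floor lies within the scatter). Compound 3 differs from compound 1 by methoxy in place of fluoro on an aromatic carbon, which gives an at least 81-fold lower number from compound 1 to compound 3 (1.91 log units; beyond the scatter) and, against compound 2, a 51-fold lower number from compound 2 to compound 3 (1.71 log units; beyond the scatter). Compound 4 `COc1ccc2c(Cn3cncn3)c(-c3ccc(Cl)cc3)[nH]c2c1` is not yet measured; it carries chloro in place of fluoro on an aromatic carbon. Going by the values given here, this is the same kind of change as the one from compound 1 to compound 2, but the place differs: there the ring is part of a fused or bridged system of two rings, meta to a fused ring and para to a fused ring; here it is a six-membered aromatic ring of carbon only, para to a large group. The earlier step of an at least 1.6-fold lower number from compound 1 to compound 2 (0.20 log units; that floor lies within the scatter) lies at a floor within the scatter. On that basis compound 4 is expected to show only a small step, a 1.5-fold lower number from compound 3 to compound 4 (0.18 log units; within the scatter). Compound 4 is estimated at 8000 nM, between 3000 nM and 25000 nM.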

Compound 4, half-maximal inhibitory concentration: 612000 nM
Estimate against measurement, compound 4: 77-fold (1.88 log units) below, outside the stated range (above it).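

In this assay, chloro in place of fluoro in the 4-fluorophenyl to 4-chlorophenyl change gives a 50-fold higher number from compound 3 to compound 4 (1.70 log units; beyond the scatter), so this change does not carry over as a fixed step between the two cores: the same change on two cores in this assay, an at least 1.6-fold lower number (0.20 log units; that floor lies within the scatter) from compound 1 to compound 2 and a 50-fold higher number (1.70 log units; beyond the scatter) from compound 3 to compound 4, at least 80-fold (1.90 log units) apart, beyond the scatter of two such steps
Compound 1 gives > 1000000 nM, which is a limit of the assay and not a number, so the earlier step is known only as a floor. The change also sits on a different ring in each pair, so these compounds do not separate the effect of the core from that of the place, and they give no cause for the gap.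

On these data alone, it remains open how a methyl or a nitrile in place of the chloro would read at that same place. A bromo on the ring of compound 1 would likewise show whether the halogen step stays small there.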